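The compounds below may be only part of what the source reports. "The series", "measured", "known", "first", "only" and "open" are said of these compounds alone.

Three compounds share one skeleton and differ only in how their two stereocentres are drawn: compound 1 `CC[C@@]1(C)C(=O)N(C(=O)NCc2ccccc2)[C@H]1Oc1ccc(C(=O)O)cc1`, compound 2 `CC[C@@]1(C)C(=O)N(C(=O)NCc2ccccc2)[C@@H]1Oc1ccc(C(=O)O)cc1` and compound 3 `CC[C@]1(C)C(=O)N(C(=O)NCc2ccccc2)[C@H]1Oc1ccc(C(=O)O)cc1`. In an ADME assay for pharmacokinetics (a higher number here means that the compound lasts longer, a lower number that the compound disappears faster), compound 1 gives 1.8 h, compound 2 gives 1.94 h and compound 3 gives 1.89 h. The steps among them are small: a 1.1-fold higher number from compound 1 to compound 2 (0.03 log units; within the scatter), a 1.1-fold higher number from compound 1 to compound 3 (0.02 log units; within the scatter) and a 1.0-fold lower number from compound 2 to compound 3 (0.01 log units; within the scatter), each within the scatter, in keeping with the fact that the pairs differ only in configuration the fact that compounds 1 and 2 differ only in the configuration as drawn the fact that compounds 1 and 3 differ only in the configuration as drawn (the fact that compounds 2 and 3 differ only in the configuration as drawn). Compound 3 therefore stands second highest of three numbers, none of which can be told apart from the others.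

Compound 4 `CC[C@]1(Cc2ccccc2)C(=O)N(C(=O)NCc2ccccc2)[C@H]1Oc1ccc(C(=O)O)cc1` departs from compound 3 by phenyl in place of hydrogen on a saturated chain carbon bound to a saturated ring carbon. Among the compounds with values here, none of the measured steps adds or removes a group; all three swap configuration only, so they offer no direct guide to this change in this assay. Within the data shown here, with no measured step bearing on the added phenyl, the expected step from compound 3 to compound 4 is set near zero, a 1.1-fold lower number from compound 3 to compound 4 (0.05 log units; within the scatter), with a wide range. Compound 4 is estimated at 1.7 h, between 0.7 h and 4 h.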

Compound 4, half-life: 12.2 h
Estimate against measurement, compound 4: 7.2-fold (0.86 log units) below, outside the stated range (above it).
By their numbers in this assay, from the lowest: compounds 1, 3 and 2 (each within the scatter of the next); then compound 4.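

In this assay, within the data shown here, phenyl in place of hydrogen on a saturated chain carbon bound to a saturated ring carbon gives a 6.5-fold higher number from compound 3 to compound 4 (0.81 log units; beyond the scatter) and is the first step here that lies beyond the scatter. This place on the molecule therefore responds to a change of group, whereas swapping configuration among compounds 1, 2 and 3 produced no readable difference. No available evidence bears on why methyl to benzyl has this effect.

The compounds shown leave open whether the aromatic ring itself matters, or whether a propyl or cyclohexylmethyl group in the same place would give a step of similar size. They also leave open whether the other configurations of compound 4 would share its longer half-life.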